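A Methyl on the Imidazole Ring of an Acylguanidine

The source may hold more compounds than are shown below. What is called first, only, known or untested is meant among the compounds shown, and "the series" means these compounds.

Compound 1 `Cc1cc(C)c(S(C)(=O)=O)cc1C(=O)N=C(N)N` is the anchor of this small set. In a functional assay for inhibition of sodium/hydrogen exchanger (Oryctolagus cuniculus) (a higher number here means a weaker inhibitor, a lower number a stronger inhibitor), compound 1 gives 11 nM. Compound 2 `Cc1c(C(=O)N=C(N)N)cc(S(C)(=O)=O)c(C)c1C` differs from compound 1 in one place: methyl in place of hydrogen on an aromatic carbon In this assay compound 2 gives 55 nM, and the step is a 5.0-fold higher number from compound 1 to compound 2 (0.70 log units; beyond the scatter). Compound 3 `Cc1cc(-n2ccnc2)c(S(C)(=O)=O)cc1C(=O)N=C(N)N` has a different core; how it differs from compound 1 is counted here: 1H-imidazol-1-yl in place of methyl on an aromatic carbon In this assay compound 3 gives 23 nM, a step of a 2.1-fold higher number from compound 1 to compound 3 (0.32 log units; beyond the scatter).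

Compound 4 `Cc1cc(-n2ccnc2C)c(S(C)(=O)=O)cc1C(=O)N=C(N)N` has not yet been measured. Among the measured compounds shown here, it differs from compound 3 in one place: methyl in place of hydrogen on an aromatic carbon This is the same kind of change as the one from compound 1 to compound 2, but not the same change: there the methyl entered on an aromatic carbon of a six-membered aromatic ring of carbon only, ortho to two methyl groups, meta to a group of 6 heavy atoms and meta to a methylsulfonyl group; here it enters on an aromatic carbon of a five-membered aromatic ring with 2 nitrogen, between two ring nitrogen atoms, next to the ring atom that bears a large group.

A rise in the number is expected for compound 4 in this assay, smaller than the earlier one because a 5.0-fold higher number from compound 1 to compound 2 (0.70 log units; beyond the scatter) was made at a different place. The step from compound 3 to compound 4 is estimated as a 2.2-fold higher number from compound 3 to compound 4 (0.34 log units; beyond the scatter). Compound 4 is expected to give about 50 nM in this assay, between 20 nM and 130 nM.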

Compound 4, half-maximal inhibitory concentration: 29 nM
Compound 4: middle estimate off by 1.7-fold (0.24 log units), on the high side; low and high end bracket the measured number.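

In this assay, among the compounds shown here, methyl in place of hydrogen on the carbon between two ring nitrogen atoms gives a 1.3-fold higher number from compound 3 to compound 4 (0.10 log units; within the scatter), so this change turns 1H-imidazol-1-yl into 2-methyl-1H-imidazol-1-yl with no step that can be told from scatter, while the comparison with the anchor still reads a 2.6-fold higher number from compound 1 to compound 4 (0.42 log units; beyond the scatter). The same replacement of hydrogen by methyl therefore does not carry over as one fixed step from the core of compound 1 to the core of compound 3: the same change on two cores in this assay, a 5.0-fold higher number (0.70 log units; beyond the scatter) from compound 1 to compound 2 and a 1.3-fold higher number (0.10 log units; within the scatter) from compound 3 to compound 4, 4.0-fold (0.60 log units) apart, beyond the scatter of two such steps. With one pair at each place, this shows only that the size of the step is not transferable between these two pairs; it does not show whether the gap follows the ring that takes the methyl or the rest of the core, and it says nothing about any other core.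

Still open, on these data alone, is whether a longer chain such as ethyl, or an amine or a carboxylic acid, on that same carbon of the five-membered ring would also leave the number in place. Also open, as far as these compounds go, is whether a second pair on either ring would repeat the step seen here.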